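Swapping the Terminal Hydroxy of Compound 1 for Methyl

The compounds below may be only part of what the source reports. "The series", "measured", "known", "first", "only" and "open" are said of these compounds alone.

Measured so far:
Compound 1, `COc1ccc2c(c1)NC(=O)CN2c1nc(NCCCO)nc2ccccc12`, gives 7.43 nM in a functional assay on MCF7 cells (Homo sapiens) for inhibition, read by sulforhodamine B assay, with a stated time of 48 h; a lower number here means a stronger inhibitor of growth, a higher number a weaker inhibitor of growth.
Compound 2, `COc1ccc2c(c1)NC(=O)CN2c1nc(Nc2cccc(C#N)c2)nc2ccccc12`, gives 384 nM in this assay.
Compound 3, `COc1ccc2c(c1)NC(=O)CN2c1nc(NCc2ccncc2)nc2ccccc12`, gives 71.8 nM in this assay.

Compound 1 has the lowest number of the three, so it is the strongest growth inhibitor of this set: the nearest is compound 3, with a 9.7-fold higher number from compound 1 to compound 3 (0.99 log units; beyond the scatter), and the furthest is compound 2, with a 52-fold higher number from compound 1 to compound 2 (1.71 log units; beyond the scatter).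

Compound 4, `CCCCNc1nc(N2CC(=O)Nc3cc(OC)ccc32)c2ccccc2n1`, is not yet measured. It differs from compound 1 in one spot: methyl in place of hydroxy on a saturated chain carbon, three bonds along the chain from a nitrogen on an aromatic ring. The chain keeps its length; only the end group changes, and with it one hydrogen-bond donor and one hydrogen-bond acceptor are lost.

Both measured steps from compound 1 replaced the whole 3-hydroxypropyl chain with a ring-bearing group, and both raised the number, by a large amount in a 52-fold higher number from compound 1 to compound 2 (1.71 log units; beyond the scatter) and a modest one in a 9.7-fold higher number from compound 1 to compound 3 (0.99 log units; beyond the scatter). Neither isolates the hydroxy itself, so they bear on compound 4 only indirectly. Still, every departure from the 3-hydroxypropyl chain seen here weakened inhibition, so a modest rise is expected, a 4.0-fold higher number from compound 1 to compound 4 (0.61 log units; beyond the scatter). Compound 4 is therefore estimated at 30 nM, within 8 nM to 120 nM.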

Compound 4, concentration for 50% growth inhibition: 7.88 nM
Compound 4: the middle estimate sits 3.8-fold (0.58 log units) above what was measured; measured number outside the range, below it.
By their numbers in this assay, from the lowest: compounds 1 and 4 (each within the scatter of the next); then compound 3; then compound 2.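

In this assay, the end of the chain tolerates this change: a 1.1-fold higher number from compound 1 to compound 4 (0.03 log units; within the scatter), so the hydroxy, with its hydrogen-bond donor and acceptor, is not required for the low number seen with compound 1. The earlier steps shown here could not show this, since each replaced the whole 3-hydroxypropyl chain. The butyl chain also stays clear of the ring-bearing groups, with a 9.1-fold lower number from compound 3 to compound 4 (0.96 log units; beyond the scatter) and a 49-fold lower number from compound 2 to compound 4 (1.69 log units; beyond the scatter) as the steps, so the higher numbers of those two compounds cannot be attributed to the absence of a hydroxy alone.

No independent measurement here explains why hydroxy and methyl read alike at this position. Still open, on these data alone, is how a shorter ethyl chain, a longer hexyl chain, or an amine or carboxylic acid at the chain end would read.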